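A few compounds are considered here, and "the series" means these few. Any claim that something is new, unique, unknown or untested is made for them only; others in the source may bear on it.

Compound 1 `CCN(Cc1ccccc1)C(=O)C1CCN(S(=O)(=O)c2ccccc2)CC1` — a functional assay on CHO cells for positive allosteric modulation of muscarinic acetylcholine receptor M5 (Homo sapiens), read by calcium flux; a lower number here means a smaller maximal response, a higher number a larger maximal response: 69%
Compound 2 `CCN(Cc1ccccc1)C(=O)C1CCN(S(=O)(=O)c2c[nH]cn2)CC1` — this assay: "not determined" (no result reported)
Compound 3 `CCN(Cc1ccccc1)C(=O)C1CCN(S(=O)(=O)c2ccccn2)CC1` — this assay: "not determined" (no result reported)

Three compounds share one core and differ only in the ring on the sulfonyl sulfur. In this assay compound 1 gives 69%. For compound 2 the result is "not determined" (no result reported). Compound 3 likewise stands without a number, its entry in this assay reading "not determined" (no result reported), so where compound 3 stands on the maximal response cannot be said. The next compound, compound 4 `CCN(Cc1ccccc1)C(=O)C1CCN(S(=O)(=O)c2ccc3[nH]ncc3c2)CC1`, is reached from compound 3 by one change: 1H-indazol-5-yl in place of pyridin-2-yl on a sulfonyl sulfur. For the measured compounds named here, no step between measured compounds is known for this change, and compound 3 itself offers no number, so the size and direction of the step cannot be read from anything measured. The only anchor in this assay is compound 1 with 69%, and a maximal response in that region is expected for compound 4 too. Compound 4 is thus estimated at 65%, within 40% to 90%, as a largest response in this assay.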

Compound 4, largest response reached (reported as percent of maximum), in percent of the reference or control that the assay uses: 86%
Compound 4: middle estimate off by 21 percentage points, on the low side, within the range that was stated.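

Replacing phenyl with 1H-indazol-5-yl on the sulfonyl sulfur gives a number 17 percentage points higher from compound 1 to compound 4 (beyond the scatter) in this assay. For the compounds shown here, this is the first comparison of two numbers at this position, and it shows that the maximal response responds to the ring placed there and that a group of two fused aromatic rings is not a loss against phenyl. The steps involving compound 2 and compound 3 cannot be read, and no measurement at hand explains the gain.

As far as these compounds go, it stays open whether the gain goes with the ring nitrogen atoms and hydrogen-bond donor of 1H-indazol-5-yl or with its second ring. Also open, from the compounds shown here alone, is how an amine or a carboxylic acid on the phenyl of compound 1 would read in this assay.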